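The source may report more compounds than this note shows. Statements on the series, on what has been measured and on what is new or still open speak of the compounds shown alone.

Of the compounds shown here, three have so far been measured in a functional assay on ACHN cells (Homo sapiens) for inhibition, read by sulforhodamine B assay, with a stated time of 48 h, tested at 10 uM; on this read-out higher numbers stand for more inhibition at the one concentration tested (going by the name of the read-out) and lower numbers for less inhibition. Compound 1 `CC(=O)c1ccc(-c2cn3ccnc3c(-c3ccc4ncn(C5CCCCC5)c4c3)n2)cc1` gives 4.32% in this assay, and compound 2 `Clc1ccc(-c2cn3ccnc3c(-c3ccc4ncn(C5CCCCC5)c4c3)n2)cc1` gives 5.45%. Among the measured compounds shown here, the only step between two measured compounds that differ in a single place is a number 1.1 percentage points higher from compound 1 to compound 2 (within the scatter), which lies within the scatter. Compound 3 `CCc1ccc(-c2cn3ccnc3c(-c3ccc4ncn(Cc5ccccc5)c4c3)n2)cc1` gives 44.7% in this assay, the highest of the three numbers; compound 2 stands nearest to it and compound 1 furthest, both beyond the scatter. Compound 3 differs from compounds 1 and 2 in two places at once, so its higher number cannot be tied to one change.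

Compound 4 `Cc1cccc(-c2cn3ccnc3c(-c3ccc4ncn(Cc5ccccc5)c4c3)n2)c1` has not yet been measured. It differs from compound 3 in this way: 3-methylphenyl in place of 4-ethylphenyl on an aromatic carbon. For the measured compounds named here, no measured step touches this part of the molecule, and the one known step concerns a different group and lies within the scatter. With nothing measured that bears on this change, the number for compound 4 is expected to stay close to that of compound 3, so the step of a number 6.7 percentage points lower from compound 3 to compound 4 (within the scatter) is expected to be small and of uncertain direction. Compound 4 is therefore estimated to give 38% in this assay, with a range from 15% to 60%.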

Compound 4, a percentage reported as inhibition, at one concentration (the size of the read-out at that concentration, not a potency): 12.4%
Estimate against measurement, compound 4: 25.6 percentage points above, outside the stated range (below it).
By their numbers in this assay, from the lowest: compounds 1, 2 and 4 (each within the scatter of the next); then compound 3.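

In this assay, replacing 4-ethylphenyl with 3-methylphenyl on the aromatic carbon of the shared core gives a number 32.3 percentage points lower from compound 3 to compound 4 (beyond the scatter), the first single-place step shown here that lies beyond the scatter. The read-out is therefore sensitive to the group at this position, and even a modest rearrangement of a carbon-only aromatic substituent can change it markedly, with no change in the counted hydrogen-bond donors, hydrogen-bond acceptors or net charge. Nothing available explains this difference.

This single step changes two features together, the alkyl group on the phenyl ring and where it sits, so the compounds shown cannot say which feature matters or whether both do; 4-methylphenyl or 3-ethylphenyl at this position would separate the two. They also leave open how a phenyl ring carrying an amine or a carboxylic acid in place of the alkyl group would read in this assay, and whether the same sensitivity holds when the rest of the molecule differs.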